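The source may hold more compounds than are shown below. What is called first, only, known or untested is meant among the compounds shown, and "the series" means these compounds.

Measured in a functional assay on MT4 cells (Homo sapiens) for cytotoxicity; on this read-out lower numbers stand for stronger inhibition and higher numbers for weaker inhibition:
- compound 1 `N#Cc1c(N)cccc1S(=O)(=O)c1ccccc1`: > 5000 nM (a limit)
- compound 2 `Cc1ccc(S(=O)(=O)c2cccc(N)c2C#N)cc1`: > 200000 nM (a limit)
- compound 3 `N#Cc1c(N)cccc1S(=O)(=O)c1ccccc1Br`: 40000 nM

Compound 1 stands only at a limit, > 5000 nM, and not at a number. Compound 4 `N#Cc1c(N)cccc1S(=O)(=O)c1cccc(Br)c1` differs from it by bromo in place of hydrogen on an aromatic carbon, a bromo in place of hydrogen on an aromatic carbon, meta to a large group. The closest measured change is the same exchange of hydrogen for bromo, a step that the limit leaves unreadable from compound 1 to compound 3. The methyl exchange, a step that the two limits leave unreadable from compound 1 to compound 2, is no more informative. Neither step gives a size, so the expectation rests mainly on compound 3 with its 40000 nM. A move toward weaker inhibition is tentatively expected, as a step that the limit leaves unreadable from compound 1 to compound 4. For compound 4 the estimated value is 35000 nM, with an expected range from 9000 nM to 150000 nM.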

Compound 4, half-maximal inhibitory concentration: > 200000 nM
Compound 4 was reported as a limit (the forecaster's own chance of this, stated with the estimate: 35%); middle value at least 5.7-fold (0.75 log units) away from the limit.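

Compound 4 stands at > 200000 nM, a limit. Among these compounds, compound 1 stands at > 5000 nM, also a limit, so no step between these two compounds can be read. The compounds shown leave open how much bromo in place of hydrogen changes the value.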